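The source may hold more compounds than are shown below. What is called first, only, known or untested is meant among the compounds shown, and "the series" means these compounds.

Measured in an ADME assay on microsomes from liver (Homo sapiens) for metabolic stability; on this read-out lower numbers stand for slow clearance and higher numbers for fast clearance:
- Compound 1 `CCCC(Oc1ccc(-n2cc(C(=O)N(C)C)cn2)cc1)c1ccc(C(=O)NCCC(=O)O)cc1`: < 13 mL/min/kg, a limit of the assay.
- Compound 2 `CCCC(Oc1ccc(-n2cc3c(n2)CCCC3)cc1)c1ccc(C(=O)NCCC(=O)O)cc1`: 48 mL/min/kg
- Compound 3 `CCCC(Oc1ccc(-n2cc(C)cn2)cc1)c1ccc(C(=O)NCCC(=O)O)cc1`: 16 mL/min/kg

Compound 3 has the lower of the two actual numbers, with a 3.0-fold lower number from compound 2 to compound 3 (0.48 log units; beyond the scatter). Against the limit of compound 1, the data show only an at least 1.2-fold higher number from compound 1 to compound 3 (0.09 log units; that floor lies within the scatter).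

Compound 4 `CCCC(Oc1ccc(-n2cc(Cl)cn2)cc1)c1ccc(C(=O)NCCC(=O)O)cc1` carries chloro in place of methyl on an aromatic carbon, two ring bonds from the ring nitrogen (chloro in place of methyl on an aromatic carbon). Going by the values given here, no measured step exchanges these two groups. The nearest guides, an at least 1.2-fold higher number from compound 1 to compound 3 (0.09 log units; that floor lies within the scatter) and a 3.0-fold lower number from compound 2 to compound 3 (0.48 log units; beyond the scatter), both involve larger groups leaving. For this one-atom exchange, no change beyond the scatter is expected in this assay, and no firm direction. The estimated step is no change at the digits printed from compound 3 to compound 4 (within the scatter). Compound 4 is expected at 16 mL/min/kg, with an estimated range of 9 mL/min/kg to 30 mL/min/kg.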

Compound 4, clearance in the Homo sapiens assay: 10 mL/min/kg
For compound 4 the middle estimate is 1.6-fold (0.20 log units) above the measured one; measured number inside the range.
By their numbers in the Homo sapiens assay, from the lowest: compounds 4 and 3 (each within the scatter of the next); then compound 2.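

At this position, two ring bonds from the ring nitrogen, chloro in place of methyl leaves the Homo sapiens assay unmoved beyond the scatter, with a 1.6-fold lower number from compound 3 to compound 4 (0.20 log units; within the scatter), while a physicochemical assay for lipophilicity, using the shake flask method, at pH 7.4 (a lower number here means a more polar compound, a higher number a more lipophilic compound), shows a number 0.50 log units higher from compound 3 to compound 4 (beyond the scatter). In the physicochemical assay compound 3 gives 2.1 and compound 4 gives 2.6. In the Homo sapiens assay, the 4-chloro-1H-pyrazol-1-yl group of compound 4 also stands clear of the larger group of compound 2, with a 4.8-fold lower number from compound 2 to compound 4 (0.68 log units; beyond the scatter). Compound 1 carries a limit, not a number, and its step to compound 4 cannot be read: the limit of < 13 mL/min/kg in the Homo sapiens assay, at which 1 of the 4 values shown sits.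

Open, going by these compounds, is how a nitrile or a trifluoromethyl at this position would read in the Homo sapiens assay and in the physicochemical assay.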